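The source may report more compounds than this note shows. Statements on the series, on what has been measured and on what is new or still open speak of the compounds shown alone.

Measured in a functional assay on SiHa cells (Homo sapiens) for antiproliferative activity, read by CCK-8 assay, with a stated time of 72 h; on this read-out lower numbers stand for stronger inhibition and higher numbers for weaker inhibition:
compound 1 `CCOC(=O)Oc1cc(-c2cncnc2-c2cc(OC)c(OC)c(OC)c2)ccc1OC` gives 1890 nM
compound 2 `COc1ccc(-c2cncnc2-c2cc(OC)c(OC)c(OC)c2)cc1Cl` gives 1330 nM
compound 3 `CCOc1ccc(-c2cncnc2-c2cc(OC)c(OC)c(OC)c2)cc1Cl` gives 150 nM

Compound 2 stands with compound 1 at the upper end of these three numbers, the two within the scatter of each other. The next structure to be read is compound 4 `COc1cc(-c2ncncc2-c2ccc3cc[nH]c3c2)cc(OC)c1OC`, and the change is 1H-indol-6-yl in place of 3-chloro-4-methoxyphenyl on an aromatic carbon. For the measured compounds named here, no measured compound carries 1H-indol-6-yl, so the measured steps bear on this one only indirectly. Both alter the group that leaves here, without replacing it whole. One barely registers, a 1.4-fold lower number from compound 1 to compound 2 (0.15 log units; within the scatter), while the other is larger, an 8.9-fold lower number from compound 2 to compound 3 (0.95 log units; beyond the scatter). These steps show that changes in this group can leave the number in place or lower it, and compound 3 at 150 nM marks how low the series has reached so far. The direction expected in this assay is therefore towards a lower number, with low confidence, and the size is expected to stay under the larger measured step. The estimated change is a 4.4-fold lower number from compound 2 to compound 4 (0.65 log units; beyond the scatter). For compound 4 the expected value is 300 nM, with an estimated range from 40 nM to 2000 nM.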

Compound 4, half-maximal inhibitory concentration: 2180 nM
Compound 4: the middle estimate sits 7.3-fold (0.86 log units) below what was measured; measured number outside the range, above it.
By their numbers in this assay, from the lowest: compound 3; then compounds 2, 1 and 4 (each within the scatter of the next).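

In this assay, exchanging the whole 3-chloro-4-methoxyphenyl group for 1H-indol-6-yl on this aromatic carbon of the six-membered aromatic ring with 2 nitrogen gives a 1.6-fold higher number from compound 2 to compound 4 (0.21 log units; within the scatter) and so leaves the number within the scatter. The earlier steps shown here altered only parts of this group, whereas here the chlorine and the methoxy oxygen leave and a fused five-membered aromatic ring with its hydrogen-bond donor enters, so a full change of the group at this position need not shift the number. Among the steps shown, an 8.9-fold lower number from compound 2 to compound 3 (0.95 log units; beyond the scatter) remains the only one beyond the scatter, and the indole swap does not reproduce it. Nothing available explains why the indole swap leaves the number within the scatter.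

On these data alone, it remains open whether the indole hydrogen matters for the number, which 1-methyl-1H-indol-6-yl would test directly. Also open, as far as these compounds go, is whether the step from methoxy to ethoxy continues to a longer chain, as in 3-chloro-4-propoxyphenyl, or whether an amine in place of the chlorine changes the number.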